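This account rests on a few compounds, and the source may have more. Where it says the series, first, only, none or still open, it means among the compounds named here.

Three compounds built on a shared core were tested in an assay on membranes from HeLa cells for displacement of a labelled ligand from adenosine receptor A3 (Homo sapiens), read by scintillation counting, with a stated time of 180 min, tested at 1 uM; a lower number here means less inhibition, a higher number more inhibition at the concentration tested (going by the name of the read-out). Compound 1 `CCCOC(=O)C1=C(C)NC(=O)NC1c1ccsc1` gives 6%. Compound 2 `CCCC(=O)C1=C(C)NC(=O)NC1c1ccsc1` gives 1%; the move of a number 5 percentage points lower from compound 1 to compound 2 (within the scatter) stays within the scatter. Compound 3 `CCSC(=O)C1=C(C)NC(=O)NC1c1cccs1` gives 1%, level with compound 2 at the digits reported; these two together make up the lowest numbers of the three, although the gap from compound 3 to compound 1 is also within the scatter. Compound 4 `CCSC(=O)C1=C(C)NC(=O)NC1c1ccsc1` has not yet been measured. It differs from compound 3 in one place: thiophen-3-yl in place of thiophen-2-yl on a saturated ring carbon. For the measured compounds named here, no measured step swaps thiophen-2-yl for thiophen-3-yl; the only measured step, from compound 1 to compound 2, changes the group on a carbonyl carbon and was within the scatter, so it bears only indirectly. Compounds 1 and 2, which carry thiophen-3-yl, and compound 3, which carries thiophen-2-yl, all sit near the bottom of the scale. Compound 4 is therefore expected to stay there, with an expected step of a number 2 percentage points higher from compound 3 to compound 4 (within the scatter). The estimate for compound 4 is 3%, between -6% and 12%.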

Compound 4, a percentage reported as inhibition, at one concentration (the size of the read-out at that concentration, not a potency): 2%
Estimate against measurement, compound 4: 1 percentage points above, and the stated range covers the measured number.
By their numbers in this assay, from the lowest: compounds 2, 3, 4 and 1 (each within the scatter of the next).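

In this assay, with the ethylsulfanyl group held on the carbonyl carbon, thiophen-3-yl in place of thiophen-2-yl on the saturated ring carbon gives a number 1 percentage points higher from compound 3 to compound 4 (within the scatter) and so shows that this swap of attachment point leaves the reading within the scatter. With thiophen-3-yl held in place, ethylsulfanyl in place of propyl on the carbonyl carbon gives a number 1 percentage points higher from compound 2 to compound 4 (within the scatter) and ethylsulfanyl in place of propoxy gives a number 4 percentage points lower from compound 1 to compound 4 (within the scatter), so these three groups also read alike here. No measured evidence is available that could explain these readings. Going by these compounds, whether an amine or a carboxylic acid in place of the thiophene, or a longer chain on the carbonyl carbon, would lift the reading stays open. Also open, on these data alone, is whether these compounds would separate at a higher concentration.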